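Oxazolyl replaces methylpyrazolyl on the amide nitrogen of compound 1

A few compounds are considered here, and "the series" means these few. Any claim that something is new, unique, unknown or untested is made for them only; others in the source may bear on it.

Compound 1 `Cc1ccc(OCC(=O)N(Cc2cccs2)c2ccnn2C)cc1` gives 422 nM in an assay on HEK293 cells for agonist activity at transient receptor potential cation channel subfamily M member 8 (Homo sapiens), read by fluorescence and calcium flux, with a stated time of 15 min (on this read-out lower numbers stand for an effect already at smaller amounts and higher numbers for an effect only at larger amounts of compound), the lowest of the three numbers seen so far. Compound 2 `CCN(Cc1ccccc1)C(=O)COc1ccc(C)cc1` gives 1880 nM and compound 3 `CCN(Cc1ccccn1)C(=O)COc1ccc(C)cc1` gives 16000 nM. Within the data shown here, the only measured single change, an 8.5-fold higher number from compound 2 to compound 3 (0.93 log units; beyond the scatter), concerns the saturated chain carbon rather than the amide nitrogen, so it bears only loosely on the present step. Compound 4 `Cc1ccc(OCC(=O)N(Cc2cccs2)c2ncco2)cc1` differs from compound 1 by 1,3-oxazol-2-yl in place of 1-methyl-1H-pyrazol-5-yl on an amide-type nitrogen. Among the measured compounds shown here, no measured step addresses an exchange at the amide-type nitrogen, so the direction remains open; the expected change is a 1.9-fold higher number from compound 1 to compound 4 (0.28 log units; within the scatter), a modest weakening with wide uncertainty. Compound 4 is therefore estimated at 800 nM, with a range from 250 nM to 2500 nM.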

Compound 4, half-maximal effective concentration: 0.3 nM
Beside the measured number, compound 4's estimate is 2700-fold (3.43 log units) above it, and the stated range ends above it.
By their numbers in this assay, from the lowest: compound 4; then compound 1; then compound 2; then compound 3.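

On the amide-type nitrogen, 1,3-oxazol-2-yl in place of 1-methyl-1H-pyrazol-5-yl gives in this assay a 1400-fold lower number from compound 1 to compound 4 (3.15 log units; beyond the scatter) and thus the largest step seen in this series. The earlier step concerned the saturated chain carbon, whereas this one shows that the number also depends strongly on the ring at the amide-type nitrogen, even though both rings match in hydrogen-bond donors, acceptors and net charge. Nothing available explains why this exchange has so large an effect.

As far as these compounds go, it remains open whether 1,3-thiazol-2-yl or 1,3-oxazol-5-yl at this nitrogen would keep the low number of compound 4.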